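Oxan-4-yl to oxan-3-yl: a small change at the carbonyl

This account rests on a few compounds, and the source may have more. Where it says the series, first, only, none or still open, it means among the compounds named here.

In an ADME assay on a cell-free system (plasma, Homo sapiens) for protein binding, tested at 1 uM, compound 3 (`O=C(Nc1ccc(OC(F)(F)F)c(F)c1)NC1CCN(C(=O)C2CCOCC2)CC1`) gives 98.5%. Compound 2 (`CC(C)C(=O)N1CCC(NC(=O)Nc2ccc(OC(F)(F)F)c(F)c2)CC1`) lies within the scatter of that at 98.7%, whereas compound 1 (`O=C(Nc1ccc(OC(F)(F)F)cc1)NC1CCN(C(=O)C2CCOCC2)CC1`) gives 94.1%. Compound 4 (`O=C(Nc1ccc(OC(F)(F)F)c(F)c1)NC1CCN(C(=O)C2CCCOC2)CC1`) carries oxan-3-yl in place of oxan-4-yl on a carbonyl carbon. The closest evidence is a 1.2-fold higher unbound fraction from compound 2 to compound 3 (0.06 log units; within the scatter), which also came from a swap on that carbonyl carbon. The larger a 3.9-fold lower unbound fraction from compound 1 to compound 3 (0.59 log units; beyond the scatter) came from fluoro in place of hydrogen on an aromatic carbon, and compound 4 keeps that fluoro. No step beyond the scatter is therefore expected in this assay. The estimated step is a 1.1-fold higher unbound fraction from compound 3 to compound 4 (0.03 log units; within the scatter). The expected value for compound 4 is 98.4%, with an estimated range of 96.8% to 99.2%.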

Compound 4, plasma protein binding: 99.4%
Compound 4: middle estimate off by 2.7-fold (0.43 log units) (unbound fraction), on the high side, and the stated range ends below it.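

In this assay the carbonyl position proves sensitive to how the ring is joined: with the same atoms, a 2.5-fold lower unbound fraction from compound 3 to compound 4 (0.40 log units; beyond the scatter) follows from oxan-3-yl in place of oxan-4-yl. Oxan-4-yl had matched isopropyl within the scatter, yet a 2.2-fold lower unbound fraction from compound 2 to compound 4 (0.34 log units; beyond the scatter) separates oxan-3-yl from isopropyl. Nothing among the available data accounts for this difference.

On these data alone, whether the same swap gives a similar step without the aromatic fluoro, on the core of compound 1, remains open. So does the outcome of placing a piperidin-4-yl ring, which carries an amine, on this carbonyl carbon.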